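Swapping chloro for fluoro on the sulfonyl aryl ring

The source may report more compounds than this note shows. Statements on the series, on what has been measured and on what is new or still open speak of the compounds shown alone.

Measured compounds:
compound 1, `Cc1ccc(S(=O)(=O)c2cnc3ccc(F)cc3c2N2CCC(C)CC2)cc1C`, 92%
compound 2, `COc1cccc(S(=O)(=O)c2cnc3ccc(F)cc3c2N2CCC(C)CC2)c1`, 90%
compound 3, `CC1CCN(c2c(S(=O)(=O)c3cccc(Cl)c3)cnc3ccc(F)cc23)CC1`, 92%

All three compounds share one core and differ only in the aryl group on the sulfonyl sulfur. In an assay on isolated protein for displacement of a labelled ligand from metabotropic glutamate receptor 5 (Homo sapiens), with a stated time of 60 min, tested at 1 uM (on this read-out lower numbers stand for less inhibition and higher numbers for more inhibition at the one concentration tested (going by the name of the read-out)), compound 3 gives 92%, level with compound 1 at the digits printed; the three readings sit close together, with a number 2 percentage points lower from compound 1 to compound 2 (within the scatter), no change at the digits printed from compound 1 to compound 3 (within the scatter) and a number 2 percentage points higher from compound 2 to compound 3 (within the scatter), none of them beyond the scatter.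

Compound 4, `CC1CCN(c2c(S(=O)(=O)c3cccc(F)c3)cnc3ccc(F)cc23)CC1`, is not yet measured. It differs from compound 3 in one place: fluoro in place of chloro on an aromatic carbon. The same difference, cut one bond further out, reads 3-chlorophenyl to 3-fluorophenyl.

For the measured compounds named here, the steps that bear on this change are the replacements on this aryl ring already seen, above all a number 2 percentage points higher from compound 2 to compound 3 (within the scatter) and no change at the digits printed from compound 1 to compound 3 (within the scatter), both small. Since every change on this ring so far stayed within the scatter, no step beyond the scatter is expected for compound 4 in this assay, with a number 2 percentage points lower from compound 3 to compound 4 (within the scatter) as the expected step. Compound 4 is therefore estimated at 90%, with a range from 82% to 96%.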

Compound 4, a percentage reported as inhibition, at one concentration (the size of the read-out at that concentration, not a potency): 76%
Compound 4: the middle estimate sits 14 percentage points above what was measured, outside the stated range (below it).
By their numbers in this assay, from the lowest: compound 4; then compounds 2, 1 and 3 (each within the scatter of the next).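

In this assay, for the compounds shown here, the aryl group on the sulfonyl sulfur proves not to be indifferent: fluoro in place of chloro on this aromatic carbon gives a number 16 percentage points lower from compound 3 to compound 4 (beyond the scatter), the first step on this ring beyond the scatter. The 3-fluorophenyl group also stands apart from the other two aryl groups, with a number 14 percentage points lower from compound 2 to compound 4 (beyond the scatter) and a number 16 percentage points lower from compound 1 to compound 4 (beyond the scatter), while 3-chlorophenyl, 3-methoxyphenyl and 3,4-dimethylphenyl read alike. Exchanging one halogen atom for another, with no change in the counted donors, acceptors or net charge, is thus enough to move the number where the earlier replacements did not.

Nothing available accounts for this step. Going by these compounds, whether a bromo or a trifluoromethyl group at this place, or a plain phenyl, would read with compound 3 or with compound 4 remains open.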